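Carbamate analogues in a writhing test: one ring swap

The source may report more compounds than this note shows. Statements on the series, on what has been measured and on what is new or still open speak of the compounds shown alone.

Compound 1: `Cc1ccc(N2CCN(CCC(OC(N)=O)c3ccccc3)CC2)c(C)c1`, 34%
Compound 2: `COc1ccc(C(CCN2CCN(c3ccc(OC)cc3)CC2)OC(N)=O)cc1`, 53%

Both compounds were tested in a functional assay on the whole organism for inhibition, with Mus musculus as the target, in the writhing test, with a stated time of 1 h, at a dose of 10 mg/kg by the oral route; on this read-out higher numbers stand for more inhibition at the one dose given (going by the name of the read-out) and lower numbers for less inhibition. Compound 2 gives 53%, the higher of the two numbers; compound 1 gives 34%, and the gap between them lies beyond the usual scatter. The two compounds differ in more than one place, so no single change can be read from that gap.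

Compound 3, `COc1ccc(N2CCN(CCC(OC(N)=O)c3ccc(C)c(C)c3)CC2)cc1`, has not been measured. It differs from compound 2 in one place only: 3,4-dimethylphenyl in place of 4-methoxyphenyl on a saturated chain carbon bound to an oxygen next to a carbonyl group and a saturated chain carbon.

Going by the values given here, no measured pair shows this exact change, so its effect is unknown. Compound 1, which also carries a 3,4-dimethylphenyl, though elsewhere in the molecule, sits lower than compound 2, and that is the only hint available. The expected step from compound 2 to compound 3 is therefore a number 9 percentage points lower from compound 2 to compound 3 (within the scatter), a modest fall that may not exceed the scatter. Compound 3 is estimated at 44%, with a range from 24% to 64%.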

Compound 3, a percentage reported as inhibition, in the whole organism at one dose (the size of the read-out at that dose, not a potency): 58%
Compound 3: middle estimate off by 14 percentage points, on the low side, and the stated range covers the measured number.
By their numbers in this assay, from the lowest: compound 1; then compounds 2 and 3 (each within the scatter of the next).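

In this assay, 3,4-dimethylphenyl in place of 4-methoxyphenyl gives a number 5 percentage points higher from compound 2 to compound 3 (within the scatter) on a saturated chain carbon bound to an oxygen next to a carbonyl group and a saturated chain carbon. Going by these compounds alone, this is the first reading of a single change, since compound 1 and compound 2 differ in more than one place, and it shows that this exchange leaves the number within the scatter even though the entering group has no oxygen and no hydrogen-bond acceptor, while the heavy-atom count stays the same. Nothing on hand accounts for the two groups reading alike.

Going by these compounds, whether a group of another kind at this place, such as 4-chlorophenyl or cyclohexyl, would move the number beyond the scatter stays open. On these data alone, the read-out is also taken at a single dose, so how compound 2 and compound 3 would compare at other doses remains unknown.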